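From hydroxymethyl to formyl on a shared core

This account rests on a few compounds, and the source may have more. Where it says the series, first, only, none or still open, it means among the compounds named here.

In a functional assay on NEC8 cells (Homo sapiens) for antiproliferative activity, read by MTT assay, with a stated time of 72 h (a lower number here means a stronger inhibitor, a higher number a weaker inhibitor), compound 1 (`C=C1CC[C@H]2O[C@@]2(C)[C@H](OC(=O)C=C(C)C)/C=C/[C@@](C)(CCC=C(C)C)C[C@H]1O`) gives 11000 nM as its reading, and compound 2 (`CC(C)=CCC[C@]1(C)/C=C/[C@@H](OC(=O)C=C(C)C)[C@]2(C)O[C@@H]2CC/C(CO)=C\C1`) gives 8400 nM as its reading. These two values lie within the usual scatter of each other, so neither compound can be ranked ahead of the other. Compound 2 therefore stands level with compound 1 on the numbers available.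

Compound 3 (`CC(C)=CCC[C@]1(C)/C=C/[C@@H](OC(=O)C=C(C)C)[C@]2(C)O[C@@H]2CC/C(C=O)=C\C1`) has not yet been measured. Its change from compound 2 is formyl in place of hydroxymethyl on a double-bonded ring carbon and the rest of the structure stays the same. Going by the values given here, no measured pair in this small set differs in one place alone, so the data offer no direct guide to the size of this change. In this assay a modest move towards a lower number is expected, although a result within the scatter would remain plausible. The expected size of the change is a 2.1-fold lower number from compound 2 to compound 3 (0.32 log units; beyond the scatter) according to this estimate. The estimated value for compound 3 is 4000 nM with an expected range from 1300 nM to 11000 nM at this stage.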

Compound 3, half-maximal inhibitory concentration: 12000 nM
For compound 3 the middle estimate is 3.0-fold (0.48 log units) below the measured one; measured number above the stated range.
By their numbers in this assay, from the lowest: compounds 2, 1 and 3 (each within the scatter of the next).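

In this assay, going by these compounds alone, formyl in place of hydroxymethyl on the double-bonded ring carbon gives a 1.4-fold higher number from compound 2 to compound 3 (0.15 log units; within the scatter), and this is the first step in the set that isolates a single place on the shared core. At this position, the two groups therefore cannot be told apart by this read-out, even though hydroxymethyl carries a hydrogen-bond donor and formyl carries none. No available measurement bears on the reason for this result.

The compounds shown leave open whether a different group on this ring carbon, such as a carboxylic acid, an amine or a longer chain, would give a step beyond the scatter. They also leave open whether formyl and hydroxymethyl would remain level if the ((2-methylprop-1-en-1-yl)carbonyl)oxy group on the shared core were replaced by another ester, such as an acetate or a benzoate.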